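The source may report more compounds than this note shows. Statements on the series, on what has been measured and on what is new or still open speak of the compounds shown alone.

Measured compounds in a functional assay on HL-60 cells (Homo sapiens) for inhibition, read by MTT assay, with a stated time of 72 h; a lower number here means a stronger inhibitor, a higher number a weaker inhibitor:
- compound 1 `COc1ccc(-c2nc(C)oc2C(=O)N2CCN(c3cccc(Cl)c3)CC2)cc1OC`: "not active" (no number reported)
- compound 2 `CCc1nc(-c2ccc(OC)c(OC)c2)c(C(=O)N2CCN(c3cccc(Cl)c3)CC2)o1`: "not active" (no number reported)
- compound 3 `COc1cc(-c2nc(C)oc2C(=O)N2CCN(c3cccc(Cl)c3)CC2)ccc1OP(=O)(O)O`: 303 nM

All three share one core and differ only in the group on the aromatic carbon of the five-membered ring. Compound 1 gives no single number in this assay, so it cannot be placed on a scale; compound 2 is in the same position, without a number. Compound 3 is the only one with a figure, and in this assay compound 3 gives 303 nM.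

Compound 4 `Cc1nc(-c2ccccc2F)c(C(=O)N2CCN(c3cccc(Cl)c3)CC2)o1` has not been measured. It differs from compound 1 in one place: 2-fluorophenyl in place of 3,4-dimethoxyphenyl on an aromatic carbon. Going by the values given here, no measured pair shows this change, so its size is open. Since compound 1 gives no number, the step from compound 1 to compound 4 cannot be stated as a difference; the expectation is that compound 4 stays weak, with a fair chance that it also gives no number. The estimate for compound 4 in this assay is 20000 nM, with a range from 3000 nM to 100000 nM.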

Compound 4, half-maximal inhibitory concentration: 39.4 nM
Estimate against measurement, compound 4: 510-fold (2.71 log units) above, and the stated range ends above it.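

Compound 1 gives no number in this assay, and compound 4 cannot be compared with it as a step. The compounds shown leave open how other groups at this place on the shared core would behave. Nothing available here explains the result of compound 4.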